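The source may hold more compounds than are shown below. What is called first, only, known or untested is meant among the compounds shown, and "the series" means these compounds.

Values measured in a functional assay on HepG2 cells (Homo sapiens) for inhibition, read by MTT assay, with a stated time of 3 days (on this read-out higher numbers stand for weaker inhibition and lower numbers for stronger inhibition), are these.

Compound 1 `COc1cc(-c2nc3ccccc3s2)ccc1OCC(=O)NNC(=O)CCl` gives 2890 nM
Compound 2 `CC[C@H](C)[C@H](NCC(=O)NNC(=O)COc1ccc(-c2nc3ccccc3s2)cc1OC)C(=O)O` gives 3540 nM
Compound 3 `COc1cc(-c2nc3ccccc3s2)ccc1OCC(=O)NNC(=O)CN[C@@H](CS)C(=O)O` gives 3120 nM

Compound 3 stands among the other two, within the scatter of both. Compound 4 `COc1cc(-c2nc3ccccc3s2)ccc1OCC(=O)NNC(=O)CN[C@@H](CS(=O)(=O)O)C(=O)O` has not yet been measured. It differs from compound 3 by sulfo in place of sulfanyl on a saturated chain carbon, two bonds along the chain from an amine nitrogen and a carbonyl carbon in one place, with sulfo in place of sulfanyl on a saturated chain carbon, two bonds along the chain from an amine nitrogen and a carbonyl carbon. The measured steps bear on this only loosely: a 1.1-fold lower number from compound 2 to compound 3 (0.05 log units; within the scatter) comes with sulfanylmethyl in place of sec-butyl, while a 1.1-fold higher number from compound 1 to compound 3 (0.03 log units; within the scatter) and a 1.2-fold higher number from compound 1 to compound 2 (0.09 log units; within the scatter) come with replacement of chloro. All three lie within the scatter, and none introduces sulfo. In this assay the expected change is a 1.1-fold higher number from compound 3 to compound 4 (0.05 log units; within the scatter) and so none beyond the scatter. For compound 4 the estimated value is 3500 nM with an expected range from 1700 nM to 7500 nM.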

Compound 4, half-maximal inhibitory concentration: 3690 nM
Compound 4: the middle estimate sits 1.1-fold (0.02 log units) below what was measured; measured number inside the range.
By their numbers in this assay, from the lowest: compounds 1, 3, 2 and 4 (each within the scatter of the next).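

In this assay sulfo in place of sulfanyl on this saturated chain carbon stays within the scatter (a 1.2-fold higher number from compound 3 to compound 4 (0.07 log units; within the scatter)). Sulfomethyl in place of sec-butyl (a 1.0-fold higher number from compound 2 to compound 4 (0.02 log units; within the scatter)) and (1-carboxy-2-sulfoethyl)amino in place of chloro (a 1.3-fold higher number from compound 1 to compound 4 (0.11 log units; within the scatter)) also stay within it, so all four compounds remain within the scatter of the next. Nothing available explains this lack of separation. The compounds shown leave open whether an amine or a carboxylic acid on this carbon would give a step beyond the scatter. On these data alone, a longer chain there remains equally open.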